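A few compounds are considered here, and "the series" means these few. Any claim that something is new, unique, unknown or untested is made for them only; others in the source may bear on it.

Measured so far, in a functional assay on NCI-H292 cells (Homo sapiens) for antiproliferative activity; a lower number here means a stronger inhibitor, a higher number a weaker inhibitor:

Compound 1 `Cc1cccc(N2C(=O)N/C(=C\c3ccc(O)cc3)C2=O)c1`: compound 1 gives > 200000 nM, which is a limit of the assay and not a number.
Compound 2 `CCOC(=O)c1ccc(N2C(=O)N/C(=C\c3ccc(O)cc3)C2=O)cc1`: compound 2 gives > 200000 nM, again a limit rather than a number.
Compound 3 `O=C(c1cccc(N2C(=O)N/C(=C\c3ccc(O)cc3)C2=O)c1)N1CCCC1`: compound 3 gives > 200000 nM, once more a limit.

Compound 2 therefore stands nowhere in particular on a scale: its value is only a limit, and every other value shown shares that same position, namely (the limit of > 200000 nM in this assay, at which 3 of the 3 values shown sit). Going by the values given here, the one step between compounds that differ in a single place, a step that the two limits leave unreadable from compound 1 to compound 3, cannot be read because both of its ends sit at the limit of > 200000 nM in this assay, at which 3 of the 3 values shown sit. So nothing measured yet tells how much any change on this aromatic ring shifts the half-maximal inhibitory concentration.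

The new compound, compound 4 `O=C(NCc1ccccc1)c1ccc(N2C(=O)N/C(=C\c3ccc(O)cc3)C2=O)cc1`, arises from compound 2 by the change (benzylamino in place of ethoxy on a carbonyl carbon). Among the compounds with values here, no measured step bears on this exchange in a readable way, and no compound in the set has yet moved off the limit. The plain expectation is that compound 4 also stays at or around the limit, with no step beyond the scatter that could be recognised. Compound 4 is thus estimated at 200000 nM, with a range from 50000 nM to 1000000 nM. For compound 4 this expected outcome corresponds to the step of a number no higher from compound 2 to compound 4 (the limit leaves the size open).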

Compound 4, half-maximal inhibitory concentration: > 200000 nM
Compound 4: no number, only a limit (the forecaster's own chance of this, stated with the estimate: 80%); the middle value sits exactly at the limit.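

Going by these compounds alone, the exchange of ethoxy for benzylamino that leads from compound 2 to compound 4 gives no step that can be read, because both compounds sit at the same limit: the limit of > 200000 nM in this assay, at which 4 of the 4 values shown sit. The compounds shown leave open which change to the shared core, if any, would give a measurable number in this assay.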